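Trading an ethyl for a fluoro on the shared core

The source may hold more compounds than are shown below. What is called first, only, known or untested is meant among the compounds shown, and "the series" means these compounds.

Of the compounds shown here, three of a shared core have been tested in a functional assay on A-375 cells (Homo sapiens) for antiproliferative activity, read by MTT assay, with a stated time of 24 h, tested at 100 ug/mL; on this read-out lower numbers stand for a weaker effect and higher numbers for a stronger effect at the one concentration tested. Compound 1 `Cc1c(C(=O)Nc2c(F)cc(-c3cccc(F)c3)cc2F)nc2ccc(F)cc2c1O` gives 51.3%, compound 2 `Cc1ccc2nc(C(=O)Nc3c(F)cc(-c4cccc(F)c4)cc3F)c(C)c(C(=O)O)c2c1` gives 37.3%, and compound 3 `CCc1ccc2nc(C(=O)Nc3c(F)cc(-c4cccc(F)c4)cc3F)c(C)c(C(=O)O)c2c1` gives 71.3%. Compound 3 therefore stands highest of the three, with compound 1 nearest and compound 2 furthest. Among the compounds with values here, the only single-change step among them runs a number 34 percentage points higher from compound 2 to compound 3 (beyond the scatter), a gain that comes from building up a methyl into an ethyl.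

Compound 4 `Cc1c(C(=O)Nc2c(F)cc(-c3cccc(F)c3)cc2F)nc2ccc(F)cc2c1C(=O)O` differs from compound 3 by fluoro in place of ethyl on an aromatic carbon. This removes the ethyl that the step from compound 2 to compound 3 rewarded, and puts a small fluoro where that chain stood. Neither compound 1 nor compound 2 carries the ethyl, and both sit well under compound 3, so the expectation for compound 4 is a drop rather than a gain. The step of a number 26.3 percentage points lower from compound 3 to compound 4 (beyond the scatter) is the expected size of that fall. Compound 4 is estimated at 45%, likely between 25% and 65%.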

Compound 4, a percentage reported as inhibition, at one concentration (the size of the read-out at that concentration, not a potency): 64.3%
The estimate for compound 4 lay 19.3 percentage points below the measured number; the measured number falls inside the stated range.
By their numbers in this assay, from the lowest: compound 2; then compound 1; then compounds 4 and 3 (each within the scatter of the next).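

In this assay, fluoro in place of ethyl on this aromatic carbon gives a number 7 percentage points lower from compound 3 to compound 4 (within the scatter) and so leaves the number unchanged within the scatter, which means that an ethyl is not needed here for a high value. Fluoro in place of methyl at the same place gives a number 27 percentage points higher from compound 2 to compound 4 (beyond the scatter) and shows that the gain over compound 2 does not depend on a longer chain, since a single fluorine atom also provides it. The other position matters too, with carboxy in place of hydroxy giving a number 13 percentage points higher from compound 1 to compound 4 (beyond the scatter) as a modest rise on the same fluoro-bearing core. On these data alone, whether a chloro, an amine or a propyl chain at the ethyl position would match compound 3 remains open. Nothing measured here explains why these numbers move.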